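The source may report more compounds than this note shows. Statements on the series, on what has been measured and on what is new or still open speak of the compounds shown alone.

Measured in a functional assay on U-937 cells (Homo sapiens) for cytotoxicity, read by MTT assay, with a stated time of 24 h; on this read-out lower numbers stand for stronger inhibition and higher numbers for weaker inhibition:
Compound 1 `COc1cc2nc(N3CCCC3)nc(NS(=O)(=O)c3ccc(C)cc3)c2cc1OC`: 8.61 ug/mL
Compound 2 `COc1cc2nc(Cl)nc(NS(=O)(=O)Cc3ccccc3)c2cc1OC`: 91.7 ug/mL

Compound 2 has the higher of these two numbers, and compound 1 lies below it by a gap beyond the scatter. Compound 3 `COc1cc2nc(Cl)nc(NS(=O)(=O)c3ccc(C)cc3)c2cc1OC` is derived from compound 2 with 4-methylphenyl in place of benzyl on a sulfonyl sulfur. Within the data shown here, no measured pair shows this change alone, so there is no direct precedent for its size. Compound 1, which also carries 4-methylphenyl on a sulfonyl sulfur, gives 8.61 ug/mL, but it also differs from compound 2 elsewhere. A moderate move towards stronger inhibition is therefore expected, and it may not clear the scatter by much. The estimated step is a 2.3-fold lower number from compound 2 to compound 3 (0.36 log units; beyond the scatter). For compound 3 the expected value is 40 ug/mL, with an estimated range of 14 ug/mL to 110 ug/mL.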

Compound 3, half-maximal inhibitory concentration: 39.9 ug/mL
Compound 3: middle estimate off by 1.0-fold (0.00 log units), on the high side, and the stated range covers the measured number.
By their numbers in this assay, from the lowest: compound 1; then compound 3; then compound 2.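

Compound 3 separates the two differences between compound 1 and compound 2, which until now could not be read apart. In this assay, with the chloro group kept, 4-methylphenyl in place of benzyl on a sulfonyl sulfur gives a 2.3-fold lower number from compound 2 to compound 3 (0.36 log units; beyond the scatter) on its own. With 4-methylphenyl kept, pyrrolidin-1-yl in place of chloro on the aromatic carbon accounts for the other step, read in reverse as a 4.6-fold higher number from compound 1 to compound 3 (0.67 log units; beyond the scatter), so both changes go with lower numbers and no information on their cause is available.

Going by these compounds, it remains open whether the methyl group matters, since a plain phenyl group on the sulfonyl sulfur would separate it from the rest of the change. On these data alone, it is also open whether other amines, such as piperidine or morpholine, would match pyrrolidin-1-yl on the aromatic carbon.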